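Cyclobutyl for Ethyl on an Amide Nitrogen: Solubility Outlook

The compounds below may be only part of what the source reports. "The series", "measured", "known", "first", "only" and "open" are said of these compounds alone.

Compound 1 `CCNC(=O)c1cc(C(=O)NC)c(=O)n(Cc2ccccc2)c1` was measured in a physicochemical assay for solubility; a higher number here means a more soluble compound, a lower number a less soluble compound. In this assay compound 1 gives >= 144 ug/mL, which is a limit of the assay rather than a number. Compound 2 `CNC(=O)c1cc(C(=O)NC2CC2)cn(Cc2cccc(F)c2)c1=O` was measured in the same way. In this assay compound 2 gives >= 133 ug/mL, again a limit of the assay rather than a number. The two limits, the limit of >= 144 ug/mL in this assay, at which 1 of the 2 values shown sits, and (the limit of >= 133 ug/mL in this assay, at which 1 of the 2 values shown sits), mark the ceiling of what the assay reports. Compound 1 therefore stands at the top of the numbers shown, and nothing separates it from compound 2; neither can be ordered against the other.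

Compound 3 `CNC(=O)c1cc(C(=O)NC2CCC2)cn(Cc2ccccc2)c1=O` has not yet been measured in this assay. It differs from compound 1 in one place: cyclobutyl in place of ethyl on an amide-type nitrogen. For the measured compounds named here, no step between measured compounds exists here, so no measured size of step is available, and because compound 1 sits at a limit, part of any change may remain hidden. The step from compound 1 to compound 3 is expected to be small, downward or none beyond the scatter: an at least 1.2-fold lower number from compound 1 to compound 3 (0.07 log units; that floor lies within the scatter). Compound 3 is expected to give 120 ug/mL, with a range from 50 ug/mL to 150 ug/mL.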

Compound 3, solubility: 28 ug/mL
Compound 3: middle estimate off by 4.3-fold (0.63 log units), on the high side; measured number below the stated range.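

For the compounds shown here, the first number in this assay that is not a limit comes with this single change at the amide-type nitrogen, and the step is an at least 5.1-fold lower number from compound 1 to compound 3 (0.71 log units; beyond the scatter). The earlier compounds shown here sat at limits and could not be ordered, whereas this pair shows that replacing ethyl with cyclobutyl at this one place, with the rest of the core of compound 1 unchanged, is enough for a step beyond the scatter. Even so, the printed size is only a lower bound, since the starting value for compound 1 is a limit and not a number: the limit of >= 144 ug/mL in this assay, at which 1 of the 3 values shown sits.

The compounds shown do not say whether the step follows the ring itself or simply the larger group, and a straight butyl chain on the same nitrogen would separate these two readings, while a ring carrying an amine would test whether the lower number can be recovered at this place. Going by these compounds alone, compound 2 carries a cyclopropyl group but also differs from compound 1 in a second place, so it gives no clean step, and how the read-out changes across ring sizes at this nitrogen remains open.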